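The source may hold more compounds than are shown below. What is called first, only, known or untested is meant among the compounds shown, and "the series" means these compounds.

Compound 1 `CS(=O)(=O)c1ccc(C(=O)N2CCC(C(=O)N3CCc4ccccc43)CC2)cc1[N+](=O)[O-]` and compound 2 `CN(CC(=O)N(Cc1ccccc1)Cc1ccccc1)C(=O)c1ccc(S(C)(=O)=O)c([N+](=O)[O-])c1` share the same core and differ in what hangs from it. In an assay on isolated protein for inhibition of thyroid hormone receptor alpha (Homo sapiens), read by fluorescence polarization (a higher number here means a weaker inhibitor, a lower number a stronger inhibitor), compound 1 gives > 60000 nM, which is a limit of the assay rather than a measured number. In this assay compound 2 gives > 60000 nM, likewise a limit. Going by the values given here, compound 1 therefore stands at the limit of > 60000 nM in this assay, at which 2 of the 2 values shown sit, and no measured step between two compounds is available to show how large a single change can move the value. Compound 3 `CN1CCN(C(=O)C2CCN(C(=O)c3ccc(S(C)(=O)=O)c([N+](=O)[O-])c3)CC2)CC1` differs from compound 1 in one place: 4-methylpiperazin-1-yl in place of 2,3-dihydro-1H-indol-1-yl on a carbonyl carbon. Because both measured compounds sit at the limit of > 60000 nM in this assay, at which 2 of the 2 values shown sit, no step beyond the usual scatter toward stronger inhibition is expected from this change; the most likely outcome is that compound 3 again reaches only the limit. The estimated value for compound 3 in this assay is 80000 nM, within a range from 20000 nM to 300000 nM. This estimate corresponds to an expected step that the limit leaves unreadable from compound 1 to compound 3.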

Compound 3, half-maximal inhibitory concentration: > 60000 nM
Compound 3 was reported as a limit; the forecaster's own chance of this, stated with the estimate: 85%; the middle value does not contradict the limit.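

Compound 1 and compound 3 both give a limit of the assay rather than a measured number, so no step between them can be read: the limit of > 60000 nM in this assay, at which 3 of the 3 values shown sit.

The compounds shown leave open how 4-methylpiperazin-1-yl and 2,3-dihydro-1H-indol-1-yl really compare, and whether any group on that carbonyl carbon gives a measurable value in this assay.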